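Cytotoxicity of a Butoxy Variant Among Three Tolerated Analogues

The source may hold more compounds than are shown below. What is called first, only, known or untested is meant among the compounds shown, and "the series" means these compounds.

Three compounds share one core and differ only in the group on one aromatic carbon. Compound 1 `CCCSc1nc(N)nc2c1ncn2/C=C1/CC1(CO)CO` carries a propylsulfanyl group, compound 2 `Nc1nc(NCc2ccccc2)c2ncn(/C=C3/CC3(CO)CO)c2n1` a benzylamino group, and compound 3 `CCCCCCOc1nc(N)nc2c1ncn2/C=C1/CC1(CO)CO` a hexyloxy group. In an ADME assay on HFF cells (Homo sapiens) for cytotoxicity, with a stated time of 8 days (a lower number here means that less compound is tolerated, a higher number that more compound is tolerated), compound 1 gives > 300000 nM, which is a limit of the assay rather than a number. In this assay compound 2 likewise reaches only the limit > 300000 nM. Compound 3 gives > 200000 nM, again a limit. Compound 2 therefore stands at the limit of > 300000 nM in this assay, at which 2 of the 3 values shown sit, while the limit of > 200000 nM in this assay, at which 1 of the 3 values shown sits, holds the remaining value. With every value a limit, the steps a step that the two limits leave unreadable from compound 1 to compound 2 and a step that the two limits leave unreadable from compound 1 to compound 3 cannot be read.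

Compound 4 `CCCCOc1nc(N)nc2c1ncn2/C=C1/CC1(CO)CO` is not yet measured; it differs from compound 2 as follows: butoxy in place of benzylamino on an aromatic carbon. The measured step that bears on this is a step that the two limits leave unreadable from compound 2 to compound 3, where a benzylamino group also gave way to an alkoxy chain. Among the compounds with values here, no measured step shows a readable size, so in this assay no step beyond the scatter is expected from compound 2 to compound 4, a number no higher from compound 2 to compound 4 (the limit leaves the size open). Compound 4 is thus expected to give about 300000 nM, within 100000 nM to 1000000 nM, most likely reported as a limit.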

Compound 4, half-maximal cytotoxic concentration: > 300000 nM
Compound 4 was reported as a limit; the forecaster's own chance of this, stated with the estimate: 85%; the middle value sits exactly at the limit.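

In this assay compound 4 gives > 300000 nM, which is a limit of the assay and not a number. Within the data shown here, compound 1, compound 2 and compound 3 also stand only at limits, so no step involving compound 4 can be read. The compounds shown leave open what concentration of each one the cells tolerate, and whether the group on the aromatic carbon changes it.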